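The compounds below may be only part of what the source reports. "The series", "measured", "known", "first", "only" and "open" are said of these compounds alone.

In an in vitro ADME assay on microsomes from liver (Simiiformes) (on this read-out higher numbers stand for a longer-lived compound and lower numbers for a shorter-lived compound), compound 3 `CCc1cc(CCCOc2c(C)cc(-c3noc(C4CC4)n3)cc2C)on1` gives 0.9 h. This lies within the usual scatter of compound 2 `COCc1cc(CCCOc2c(C)cc(-c3noc(C(F)(F)F)n3)cc2C)on1` at 1.58 h, while compound 1 `CCc1cc(CCCOc2c(C)cc(-c3noc(C)n3)cc2C)on1` gives 0.183 h. Compound 4 `CCc1cc(CCCOc2c(C)cc(-c3noc(C(F)(F)F)n3)cc2C)on1` has not yet been measured. It puts trifluoromethyl in place of cyclopropyl on an aromatic carbon of compound 3: trifluoromethyl in place of cyclopropyl on an aromatic carbon. For the measured compounds named here, the only measured step at this place is modest and beyond the scatter, a 4.9-fold higher number from compound 1 to compound 3 (0.69 log units; beyond the scatter), but it involves methyl and cyclopropyl, not trifluoromethyl. Compound 2 at 1.58 h does carry trifluoromethyl, though it differs from compound 4 elsewhere, so it is only a rough guide. The expected step is small and within the scatter, a 1.4-fold higher number from compound 3 to compound 4 (0.16 log units; within the scatter). For compound 4 the estimated half-life is 1.3 h, with an expected range from 0.6 h to 2.8 h.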

Compound 4, half-life: > 2.5 h
Compound 4: no number, only a limit; the forecaster's own chance of this, stated with the estimate: 3%; middle value at least 1.9-fold (0.28 log units) away from the limit.
By their numbers in this assay, from the lowest: compound 1; then compounds 3 and 2 (each within the scatter of the next). At a limit, above all of these: compound 4.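

On this carbon of the five-membered ring, trifluoromethyl gives a longer half-life than either cyclopropyl or methyl in this assay, with an at least 2.7-fold higher number from compound 3 to compound 4 (0.44 log units; beyond the scatter) and an at least 13-fold higher number from compound 1 to compound 4 (1.13 log units; beyond the scatter), so the gain from cyclopropyl was not the most this position allows. Methyl in place of methoxy on the side chain gives an at least 1.5-fold higher number from compound 2 to compound 4 (0.19 log units; that floor lies within the scatter), so no gain from that change can be claimed. Compound 4 gives only a limit, not a number: the limit of > 2.5 h in this assay, at which 1 of the 4 values shown sits.

From the compounds shown here alone, how far the half-life of compound 4 extends past that limit remains open. So does the effect of an amine or a longer chain at this ring carbon.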